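A few compounds are considered here, and "the series" means these few. Any claim that something is new, unique, unknown or untested is made for them only; others in the source may bear on it.

Of the compounds shown here, two built on one shared core have so far been tested in an assay on isolated protein for inhibition of vascular endothelial growth factor receptor 2 (Danio rerio), read by fluorescence and microscopy, with a stated time of 33 h; on this read-out higher numbers stand for weaker inhibition and lower numbers for stronger inhibition. Compound 1 `O=C(Nc1cccc(Oc2ncnc3[nH]ncc23)c1)c1ccc(C(F)(F)F)cc1` gives in this assay a value of > 100000 nM, which is a limit of the assay rather than a measured number. Compound 2 `O=C(Nc1ccc(Oc2ncnc3[nH]ncc23)cc1)Nc1cccnc1` gives in this assay a value of > 100000 nM, again a limit rather than a number. Among the compounds with values here, compound 2 thus stands at the limit, and the only other value shown sits there too, as the limit of > 100000 nM in this assay, at which 2 of the 2 values shown sit, records. Compound 3 `O=C(Nc1ccc(Oc2ncnc3[nH]ncc23)cc1)Nc1cccc(F)c1` has not yet been measured. It differs from compound 2 in one place: 3-fluorophenyl in place of pyridin-3-yl on an amide-type nitrogen. With both measured compounds at the limit, no step beyond the usual scatter is expected in this assay, in either direction. The expected step from compound 2 to compound 3 is a number no higher from compound 2 to compound 3 (the limit leaves the size open). Compound 3 is expected to give 100000 nM, within a range from 20000 nM to 300000 nM, and most likely to be reported only as a limit.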

Compound 3, half-maximal inhibitory concentration: 16600 nM
Estimate against measurement, compound 3: 6.0-fold (0.78 log units) above, outside the stated range (below it).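

In this assay, the group on the amide-type nitrogen turns out to matter: 3-fluorophenyl in place of pyridin-3-yl gives an at least 6.0-fold lower number from compound 2 to compound 3 (0.77 log units; beyond the scatter). Within the data shown here, compound 3 is the first compound here with a measured number rather than a limit, so this change moves the series into the range that the assay can read. The true size of the step stays open because its starting point, compound 2, is only a limit, and limits still make up most of the record: the limit of > 100000 nM in this assay, at which 2 of the 3 values shown sit.

The change removes a ring nitrogen and adds a fluorine in one move, and the compounds shown cannot separate these two parts, which a plain phenyl on the same nitrogen could begin to do. As far as these compounds go, whether other ring substituents, such as chlorine or methoxy, would give lower numbers also remains open.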